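Moving from 3,4-dichlorophenyl to 2,4-dichlorophenyl: an expected half-life

The source may hold more compounds than are shown below. What is called first, only, known or untested is meant among the compounds shown, and "the series" means these compounds.

In an ADME assay on S9 fraction from liver (Mus musculus, strain ICR/CD-1) for metabolic stability, read by LC-MS, using NADPH, with a stated time of 5 min, tested at 2 uM (on this read-out lower numbers stand for a shorter-lived compound and higher numbers for a longer-lived compound), compound 1 (`Cc1cc(Cl)cc(Cl)c1S(=O)(=O)N1CCC(N2CCC(C)CC2)CC1`) gives 0.12 h, compound 2 (`CC1CCN(C2CCN(S(=O)(=O)c3ccc(Br)c(Cl)c3)CC2)CC1`) gives 0.717 h and compound 3 (`CC1CCN(C2CCN(S(=O)(=O)c3ccc(Cl)c(Cl)c3)CC2)CC1`) gives 0.55 h. Compound 3 and compound 2 lie within the scatter of each other at the upper end of these three numbers, while compound 1 lies clearly below both, beyond the scatter.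

Compound 4 (`CC1CCN(C2CCN(S(=O)(=O)c3ccc(Cl)cc3Cl)CC2)CC1`) has 2,4-dichlorophenyl in place of 3,4-dichlorophenyl on a sulfonyl sulfur. The two have the same atoms, joined differently.

For the measured compounds named here, the only measured step, a 1.3-fold lower number from compound 2 to compound 3 (0.12 log units; within the scatter), is chloro in place of bromo on an aromatic carbon. That is a different kind of change, and it stayed within the scatter, so it offers little guidance here. Going by the values given here, no measured pair isolates a move of this kind. The nearest hint is compound 1 at 0.12 h, whose aromatic ring resembles 2,4-dichlorophenyl more closely than 3,4-dichlorophenyl does, though it also differs in other ways.

A modest fall is therefore expected, probably not beyond the scatter, and the estimated change is a 1.8-fold lower number from compound 3 to compound 4 (0.26 log units; within the scatter). The half-life of compound 4 is estimated at 0.3 h, with an expected range of 0.13 h to 0.65 h.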

Compound 4, half-life: 0.25 h
Compound 4: middle estimate off by 1.2-fold (0.08 log units), on the high side, and the stated range covers the measured number.
By their numbers in this assay, from the lowest: compound 1; then compound 4; then compounds 3 and 2 (each within the scatter of the next).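

Placing 2,4-dichlorophenyl in place of 3,4-dichlorophenyl on a sulfonyl sulfur changes only how the same atoms are joined, and in this assay it gives a 2.2-fold lower number from compound 3 to compound 4 (0.34 log units; beyond the scatter) as the first step beyond the scatter that isolates this arrangement on the ring. The comparison with the bromo-bearing ring runs the same way, with 2,4-dichlorophenyl in place of 4-bromo-3-chlorophenyl giving a 2.9-fold lower number from compound 2 to compound 4 (0.46 log units; beyond the scatter), whereas the earlier exchange of bromo for chloro had stayed within the scatter, so among these compounds the arrangement of the halogens counts for more than the identity of one of them. The methyl group on the ring also matters, since hydrogen in place of methyl on an aromatic carbon gives a 2.1-fold higher number from compound 1 to compound 4 (0.32 log units; beyond the scatter), which separates that single group from the other differences the earlier comparison left tangled. Nothing given here accounts for any of these shifts.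

From the compounds shown here alone, it remains open whether the same rearrangement would shift the half-life with fluoro or methoxy groups on the ring in place of chloro. The compounds shown also leave open how a single chloro group, or an amine on this ring, would compare with these dihalogenated rings.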